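The source may report more compounds than this note shows. Statements on the series, on what has been measured and on what is new or still open speak of the compounds shown alone.

Compound 1 `COc1ccc(CNC(=O)CSc2nc3ccc(NC(=O)c4ccc(Cl)cc4)cc3s2)cc1` in a functional assay on MCF7 cells (Homo sapiens) for cytotoxicity, read by MTT assay, with a stated time of 48 h (a lower number here means a stronger inhibitor, a higher number a weaker inhibitor), gives 19200 nM. Compound 2 `O=C(CSc1nc2ccc(NC(=O)c3ccc([N+](=O)[O-])cc3)cc2s1)NCc1ccc(Cl)cc1` returns only a limit in this assay, > 100000 nM. Compound 3 `COc1ccc(CNC(=O)CSc2nc3ccc(NC(=O)c4ccc([N+](=O)[O-])cc4)cc3s2)cc1` likewise returns only a limit, > 100000 nM. Compound 3 thus sits at the limit of > 100000 nM in this assay, at which 2 of the 3 values shown sit, and its number is not known beyond that. Among the compounds with values here, the one readable comparison is an at least 5.2-fold higher number from compound 1 to compound 3 (0.71 log units; beyond the scatter), while a step that the two limits leave unreadable from compound 2 to compound 3 tells nothing about the benzylic substituent.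

Compound 4 `COc1ccc(CNC(=O)CSc2nc3ccc(NC(=O)c4ccccc4OC)cc3s2)cc1` differs from compound 3 by 2-methoxyphenyl in place of 4-nitrophenyl on a carbonyl carbon. Within the data shown here, no measured step covers this change directly. The nearest is the step from compound 1 to compound 3, which the new change partly undoes by removing the nitro group. A return toward the level of compound 1 is therefore expected, with the step of an at least 2.8-fold lower number from compound 3 to compound 4 (0.45 log units; beyond the scatter) as the estimate. Compound 4 is expected at 35000 nM, within 8000 nM to 150000 nM.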

Compound 4, half-maximal inhibitory concentration: 9300 nM
Beside the measured number, compound 4's estimate is 3.8-fold (0.58 log units) above it, within the range that was stated.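

On the carbonyl carbon, 2-methoxyphenyl in place of 4-nitrophenyl gives an at least 10-fold lower number from compound 3 to compound 4 (1.03 log units; beyond the scatter), so measurable activity at this position is not confined to the 4-chlorophenyl amide. Replacing 4-chlorophenyl with 2-methoxyphenyl gives a 2.1-fold lower number from compound 1 to compound 4 (0.31 log units; beyond the scatter), a modest gain. The first step has only a lower bound, as compound 3 is a limit, not a number: the limit of > 100000 nM in this assay, at which 2 of the 4 values shown sit.

On these data alone, whether the methoxy group itself or its place on the ring carries the change stays open. Also open, as far as these compounds go, is how an amine or a carboxylic acid on this aromatic ring would read in this assay.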